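The source may hold more compounds than are shown below. What is called first, only, known or untested is meant among the compounds shown, and "the series" means these compounds.

Measured in a functional assay on SiHa cells (Homo sapiens) for inhibition, read by sulforhodamine B assay; on this read-out lower numbers stand for stronger inhibition of growth and higher numbers for weaker inhibition of growth
- compound 1 `Cc1ccc2[nH]c(-c3ccc(-c4ccc(-c5ccc(N(C)C)cc5)cc4)cc3)nc2c1` gives 7110 nM
- compound 2 `CN(C)c1ccc(-c2ccc(-c3ccc(-c4nc5ccccc5[nH]4)cc3)cc2)cc1` gives 100000 nM

Compound 1 holds the lower of these two numbers, so it is the stronger growth inhibitor of the pair. Compound 3 `Cc1ccc2[nH]c(-c3ccc(-c4ccc(-c5ccccc5)cc4)cc3)nc2c1` keeps the core of compound 1 and makes a single change, (hydrogen in place of dimethylamino on an aromatic carbon), which is hydrogen in place of dimethylamino on an aromatic carbon, para to a large group.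

For the measured compounds named here, the only measured step is a 14-fold higher number from compound 1 to compound 2 (1.15 log units; beyond the scatter) and it involves the methyl group, not the dimethylamino group. Going by the values given here, it shows that one small change can move the number in this assay by a large amount, but no measured compound lacks dimethylamino, so it gives only a loose guide to size. A moderate step towards a higher number is expected, with wide uncertainty. For compound 3 the estimated value is 20000 nM, within a range of 6000 nM to 100000 nM. This estimate means an expected 2.8-fold higher number from compound 1 to compound 3 (0.45 log units; beyond the scatter) overall.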

Compound 3, concentration for 50% growth inhibition: 35200 nM
The estimate for compound 3 lay 1.8-fold (0.25 log units) below the measured number; low and high end bracket the measured number.
By their numbers in this assay, from the lowest: compound 1; then compound 3; then compound 2.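

In this assay, cutting 4-(dimethylamino)phenyl back to phenyl gives a 5.0-fold higher number from compound 1 to compound 3 (0.69 log units; beyond the scatter) and so shows that the number also depends on the dimethylamino group at this position, which the earlier pair, differing only in a methyl group, could not show. This step is modest, whereas removing the methyl group gives a 14-fold higher number from compound 1 to compound 2 (1.15 log units; beyond the scatter) and counts as large, so in this series the dimethylamino group moves the number less than the methyl group does.

As far as these compounds go, whether a primary amine or a methoxy group in the same place would hold the lower number remains open, as does whether the two steps would add up in a compound lacking both groups. Nothing available explains why the number moves with this change.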